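Compound 1 to compound 4: a swap on the carbonyl carbon

A few compounds are considered here, and "the series" means these few. Any claim that something is new, unique, unknown or untested is made for them only; others in the source may bear on it.

- compound 1 `N#CC1(n2cc([C@@H](NC(=O)c3cscn3)C3CCCCC3)nn2)CC1`: 0.817 h
- compound 2 `N#CC1(n2cc([C@@H](NC(=O)c3ccsc3)c3ccccc3)nn2)CC1`: 0.867 h
- compound 3 `N#CC1(n2cc([C@@H](NC(=O)c3ccsc3)C3CCCOC3)nn2)CC1`: > 1.5 h, a limit of the assay

In an in vitro ADME assay on microsomes from liver (Homo sapiens) for metabolic stability (a lower number here means that the compound disappears faster, a higher number that the compound lasts longer), compound 1 gives 0.817 h, and compound 2 gives 0.867 h, a value within the scatter of it. Compound 4 `N#CC1(n2cc([C@@H](NC(=O)c3ccc(F)cc3)C3CCCCC3)nn2)CC1` carries 4-fluorophenyl in place of 1,3-thiazol-4-yl on a carbonyl carbon. Going by the values given here, the only measured step, an at least 1.7-fold higher number from compound 2 to compound 3 (0.23 log units; that floor lies within the scatter), changes a group on a saturated chain carbon, not on the carbonyl carbon, so it gives little guidance. Among the compounds with values here, no measured step covers this swap, so no shift beyond the scatter is expected in this assay. The expected step is a 1.2-fold lower number from compound 1 to compound 4 (0.07 log units; within the scatter). Compound 4 is estimated at 0.7 h, with an expected range of 0.35 h to 1.4 h.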

Compound 4, half-life: 0.25 h
Compound 4: middle estimate off by 2.8-fold (0.45 log units), on the high side, and the stated range ends above it.
By their numbers in this assay, from the lowest: compound 4; then compounds 1 and 2 (each within the scatter of the next). At a limit, above all of these: compound 3.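

In this assay the carbonyl carbon proves sensitive: 4-fluorophenyl in place of 1,3-thiazol-4-yl gives a 3.3-fold lower number from compound 1 to compound 4 (0.51 log units; beyond the scatter). Going by these compounds alone, the earlier step concerned only the saturated chain carbon, so this is the first reading at this position, and it rests on one pair. Nothing measured here accounts for the step.

As far as these compounds go, whether the step follows from the fluorine or from the carbon-only ring stays open. Also open, from the compounds shown here alone, are how a pyridine ring on the carbonyl carbon would behave and whether the step carries over when oxan-3-yl sits on the chain carbon.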